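This account rests on a few compounds, and the source may have more. Where it says the series, first, only, none or still open, it means among the compounds named here.

Measured compounds:
- compound 1, `NCCn1ncc2c(NCc3ccccc3[N+](=O)[O-])cc(C(F)(F)F)cc21`, gives 30% in an assay for inhibition of Indoleamine 2,3-dioxygenase 1 (Homo sapiens), with stated times of 10 min and 60 min, tested at 100 uM; a higher number here means a stronger effect of the compound at the concentration tested, a lower number a weaker effect
- compound 2, `O=[N+]([O-])c1ccc(CNc2cc(Br)cc3[nH]ncc23)cc1`, gives 87% in this assay
- compound 3, `FC(F)(F)c1cc(NCC2CNC2)c2cn[nH]c2c1`, gives 22% in this assay

Among these three, compound 1 stands second highest. Its number is close to that of compound 3, and the gap between them lies within the scatter of this kind of measurement, so the two cannot be told apart. Compound 2 gives a much higher number, and that gap lies beyond the scatter.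

Compound 4, `CC(C)n1ncc2c(NCc3ccccc3[N+](=O)[O-])cc(C(F)(F)F)cc21`, has not yet been measured in this assay. It is compound 1 with a single change: isopropyl in place of 2-aminoethyl on an aromatic nitrogen. Going by the values given here, no pair of measured compounds here differs in that one place, so nothing among the measured data shows what this change does. Both groups count the same number of heavy atoms, and the core of compound 1 stays the same. Among the compounds with values here, with no comparable step to lean on, the expectation for compound 4 is a step from compound 1 of a size no larger than the scatter, in either direction, estimated as a number 2 percentage points lower from compound 1 to compound 4 (within the scatter). Compound 4 is therefore expected to give about 28% in this assay, with a range from 5% to 55%.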

Compound 4, a percentage reported as inhibition, at one concentration (the size of the read-out at that concentration, not a potency): 13%
For compound 4 the middle estimate is 15 percentage points above the measured one, and the stated range covers the measured number.
By their numbers in this assay, from the lowest: compounds 4, 3 and 1 (each within the scatter of the next, the first and the last beyond it); then compound 2.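

Swapping 2-aminoethyl for isopropyl on the aromatic nitrogen gives a number 17 percentage points lower from compound 1 to compound 4 (beyond the scatter) in this assay, the first direct comparison at this position. The group placed on this nitrogen can therefore change the read-out even when the heavy-atom count stays the same, as it does for these two groups, so the result depends on more than the size of the group measured that way. The groups also differ in their counts, with 2-aminoethyl carrying one hydrogen-bond donor and one hydrogen-bond acceptor and isopropyl carrying neither, but no measurement here connects that difference, or any other, to the step.

With the core of compound 1 held fixed, the compounds shown leave open what a plain hydrogen, a methyl, a 2-hydroxyethyl or a longer 3-aminopropyl chain on this nitrogen would give, and such groups would help separate the role of the chain's amine from that of its shape. They also leave open whether a step of this size would recur if the same swap were made with a bromine in place of trifluoromethyl on the core.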